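Pentyl in place of the fluorophenylpropyl chain

A few compounds are considered here, and "the series" means these few. Any claim that something is new, unique, unknown or untested is made for them only; others in the source may bear on it.

Measured so far:
- compound 1, `Nc1nc(N2CCN(C(=O)COc3ccc(Cl)cc3)CC2)c2nc(-c3ccc(F)cc3)sc2n1`: 490 nM
- compound 2, `Nc1nc(N2CCN(C(=O)COc3ccc(Cl)cc3)CC2)c2nc(CCCc3ccc(F)cc3)sc2n1`: 960 nM

In a functional assay on cells (Lymphocyte, Homo sapiens) (a lower number here means a stronger inhibitor, a higher number a weaker inhibitor), compound 1 gives 490 nM. Compound 2, `Nc1nc(N2CCN(C(=O)COc3ccc(Cl)cc3)CC2)c2nc(CCCc3ccc(F)cc3)sc2n1`, gives 960 nM in this assay. For the measured compounds named here, compound 2 has the higher of the two numbers, but the one step of a 2.0-fold higher number from compound 1 to compound 2 (0.29 log units; within the scatter), so the two compounds cannot be ranked on these data.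

Compound 3, `CCCCCc1nc2c(N3CCN(C(=O)COc4ccc(Cl)cc4)CC3)nc(N)nc2s1`, is not yet measured. It differs from compound 2 by ethyl in place of 4-fluorophenyl on a saturated chain carbon, three bonds along the chain from an aromatic carbon. Going by the values given here, the only measured step that bears on this is a 2.0-fold higher number from compound 1 to compound 2 (0.29 log units; within the scatter), which shows that stretching the 4-fluorophenyl out on a three-carbon chain changed little. Nothing measured here shows what happens when the ring itself is taken away and only a saturated chain remains, so the expectation is uncertain. The expected step of a 1.6-fold higher number from compound 2 to compound 3 (0.19 log units; within the scatter) is a small loss, which may well stay within the scatter. Compound 3 is therefore estimated at 1500 nM in this assay, with a range from 500 nM to 5000 nM.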

Compound 3, half-maximal inhibitory concentration: 690 nM
The estimate for compound 3 lay 2.2-fold (0.34 log units) above the measured number; measured number inside the range.
By their numbers in this assay, from the lowest: compounds 1, 3 and 2 (each within the scatter of the next).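

In this assay, replacing the 4-fluorophenyl at the end of the chain with ethyl, which turns the 3-(4-fluorophenyl)propyl into pentyl, gives a 1.4-fold lower number from compound 2 to compound 3 (0.14 log units; within the scatter), so the two compounds cannot be told apart. Pentyl in place of the 4-fluorophenyl on an aromatic carbon gives a 1.4-fold higher number from compound 1 to compound 3 (0.15 log units; within the scatter), so this pair cannot be separated either. The new information is that a plain saturated chain with no ring at all sits within the scatter of both ring-bearing compounds, so among these three compounds, an aromatic ring at this position is not required for activity in this range.

No measurement shown here explains this result. The compounds shown leave open whether a much shorter group such as methyl, or a chain ending in an amine or a carboxylic acid, would also stay in this range at this position.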